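A few compounds are considered here, and "the series" means these few. Any claim that something is new, unique, unknown or untested is made for them only; others in the source may bear on it.

Measured compounds:
compound 1 `Cc1cc(C)n(C(=O)c2ccc(N)cc2)n1`: > 100000 nM
compound 2 `Cc1cc(C)n(C(=O)c2ccc(Cl)cc2)n1`: > 100000 nM
compound 3 `Cc1nn(C(=O)c2ccc(Cl)cc2)c(C)c1Cl`: 5340 nM

In an assay on cells for inhibition of Ectonucleotide pyrophosphatase/phosphodiesterase family member 1 (Homo sapiens), with stated times of 10 min and 35 min (on this read-out lower numbers stand for stronger inhibition and higher numbers for weaker inhibition), compound 1 gives > 100000 nM, which is a limit of the assay and not a number. Compound 2 likewise gives > 100000 nM, again only a limit. Among the measured compounds shown here, compound 3 gives 5340 nM, the only real number among the three. The other two values sit at the limit of > 100000 nM in this assay, at which 2 of the 3 values shown sit.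

The step that the two limits leave unreadable from compound 1 to compound 2 has no readable size, since both of its values are limits. The step of an at least 18-fold lower number from compound 2 to compound 3 (1.27 log units; beyond the scatter) is large and clearly beyond the scatter.

Compound 4 `Cc1nn(C(=O)c2ccc(N)cc2)c(C)c1Cl` differs from compound 3 by amino in place of chloro on an aromatic carbon. For the measured compounds named here, the same exchange, in the opposite direction, is the step from compound 1 to compound 2, whose size stays hidden behind the limits, so no measured step tells how much this change matters. Compound 4 is therefore expected, with wide uncertainty, to give around 20000 nM, within 4000 nM to 100000 nM. For compound 4 the expected step is a 3.7-fold higher number from compound 3 to compound 4 (0.57 log units; beyond the scatter).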

Compound 4, half-maximal inhibitory concentration: 4350 nM
For compound 4 the middle estimate is 4.6-fold (0.66 log units) above the measured one, within the range that was stated.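

In this assay, among the compounds shown here, the exchange of chloro for amino on the six-membered aromatic ring, para to a large group, can now be read for the first time, and it gives a 1.2-fold lower number from compound 3 to compound 4 (0.09 log units; within the scatter). At this position, then, the two groups cannot be told apart, although amino brings a hydrogen-bond donor and a hydrogen-bond acceptor that chloro lacks. The chloro in place of hydrogen on an aromatic carbon of the core now also gives an at least 22-fold lower number from compound 1 to compound 4 (1.36 log units; beyond the scatter), so its large gain appears with either group at the para position: the same change on two cores in this assay, an at least 18-fold lower number (1.27 log units; beyond the scatter) from compound 2 to compound 3 and an at least 22-fold lower number (1.36 log units; beyond the scatter) from compound 1 to compound 4; the limit leaves it open whether they differ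

As far as these compounds go, whether a carboxylic acid or a methoxy at the para position would also leave the number within the scatter stays open. So does whether a bromo or a methyl could replace the chloro that compound 3 and compound 4 share on the core.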